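Compound 4 in the Raji cell series

The source may hold more compounds than are shown below. What is called first, only, known or untested is meant among the compounds shown, and "the series" means these compounds.

Values in an ADME assay on Raji cells (Homo sapiens) for cytotoxicity, with a stated time of 72 h (a higher number here means that more compound is needed for the effect, a lower number that less compound is needed), for the measured compounds:
Compound 1 `Cc1cc(NC(=O)Nc2cccc([N+](=O)[O-])c2)c2ccccc2n1` gives > 25000 nM as a limit
Compound 2 `Cc1cc(NC(=O)Nc2ccc(F)cc2)c2ccccc2n1` gives > 25000 nM as a limit
Compound 3 `Cc1cc(NC(=O)Nc2cccc(N(C)C)c2)c2ccccc2n1` gives > 25000 nM as a limit

Compound 3 stands at > 25000 nM in this assay and this is a limit, not a number. The next change puts tert-butyl in place of dimethylamino on an aromatic carbon and gives compound 4 `Cc1cc(NC(=O)Nc2cccc(C(C)(C)C)c2)c2ccccc2n1` as the result. Within the data shown here, the one measured step bearing on this change is a step that the two limits leave unreadable from compound 1 to compound 3 and it offers no size to carry over. Among the measured compounds shown here, the series so far comes down to the limit of > 25000 nM in this assay, at which 3 of the 3 values shown sit, and none of the three compounds gives a number. No readable step and no direction can therefore be taken from the data, so none beyond the scatter is expected in this assay for this change. The expected step is a step that the limit leaves unreadable from compound 3 to compound 4 as an estimate only. Compound 4 is expected at 30000 nM with an estimated range from 12000 nM to 60000 nM and the assay will most likely report only a limit again.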

Compound 4, half-maximal effective concentration: > 25000 nM
Compound 4 ended at the assay's limit (the forecaster's own chance of this, stated with the estimate: 80%); the middle value does not contradict the limit.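

In this assay compound 4 gives > 25000 nM, which is a limit and not a number. The steps to compound 4 from compound 1 and compound 3 therefore cannot be read. The compounds shown leave open what number any of them would give in this assay: the limit of > 25000 nM in this assay, at which 4 of the 4 values shown sit.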